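Aryl variation on the tetrazole: positional isomer step

The source may report more compounds than this note shows. Statements on the series, on what has been measured and on what is new or still open speak of the compounds shown alone.

Measured compounds:
compound 1 `Cc1cc(NC(=O)Cn2nnc(-c3cc(Cl)cc(Cl)c3)n2)n(C2CCCCC2)n1` — 82%
compound 2 `Cc1cc(NC(=O)Cn2nnc(-c3cccc(F)c3)n2)n(C2CCCCC2)n1` — 96%
compound 3 `COc1ccc(-c2nnn(CC(=O)Nc3cc(C)nn3C3CCCCC3)n2)cc1` — 90%

In an assay on HEK293 cells for activation of Kir3.1/Kir3.2 (Homo sapiens), read by thallium flux (a lower number here means a smaller maximal response, a higher number a larger maximal response), compound 3 stands second of three; it sits within the scatter of compound 2 and within the scatter of compound 1, so no order among the three is claimed. The change to compound 4 `COc1cccc(-c2nnn(CC(=O)Nc3cc(C)nn3C3CCCCC3)n2)c1` is 3-methoxyphenyl in place of 4-methoxyphenyl on an aromatic carbon. Within the data shown here, no measured step moves a methoxy group around the ring. The nearest comparison, a number 6 percentage points lower from compound 2 to compound 3 (within the scatter), sets a 3-substituted aryl against a 4-substituted one and stays within the scatter; a number 14 percentage points higher from compound 1 to compound 2 (beyond the scatter) and a number 8 percentage points higher from compound 1 to compound 3 (within the scatter) concern different groups. The expected step is therefore a number 2 percentage points higher from compound 3 to compound 4 (within the scatter), none beyond the scatter. For compound 4 the estimate in this assay is 92%, range 80% to 102%.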

Compound 4, largest response reached (Emax), in percent of the reference or control that the assay uses: 76%
Compound 4: the middle estimate sits 16 percentage points above what was measured; the measured number lies below the stated range.
By their numbers in this assay, from the lowest: compounds 4, 1, 3 and 2 (each within the scatter of the next, the first and the last beyond it).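

In this assay the place of the methoxy group counts on its own, with a number 14 percentage points lower from compound 3 to compound 4 (beyond the scatter) for the same atoms joined differently. The substituent also counts, with a number 20 percentage points lower from compound 2 to compound 4 (beyond the scatter) for methoxy in place of fluoro, while a number 6 percentage points lower from compound 1 to compound 4 (within the scatter) sets 3-methoxyphenyl and 3,5-dichlorophenyl in no order. No available data account for these steps. Open, on these data alone, is whether the response depends on the place of groups other than methoxy. Also open, as far as these compounds go, is how unsubstituted phenyl, or an aryl ring bearing an amine or a carboxylic acid, would compare.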